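The source may hold more compounds than are shown below. What is called first, only, known or untested is meant among the compounds shown, and "the series" means these compounds.

The series rests on a shared core carrying a hydrazone-linked aryl group, and it is followed in an assay on CHO-K1 cells for displacement of a labelled ligand from adenosine receptor A1 (Homo sapiens), read by scintillation counting, with a stated time of 60 min; a lower number here means a stronger inhibitor, a higher number a weaker inhibitor. Compound 1 `Nc1nc(N/N=C/c2cccc(OCc3ccccc3)c2)nc2c1ncn2[C@@H]1O[C@H](CO)[C@@H](O)[C@H]1O` gives 13 nM in this assay. Compound 2 `COc1cc(/C=N/Nc2nc(N)c3ncn([C@@H]4O[C@H](CO)[C@@H](O)[C@H]4O)c3n2)ccc1OCc1ccccc1` gives 9140 nM in this assay. Compound 3 `Nc1nc(N/N=C/c2ccc3ncccc3c2)nc2c1ncn2[C@@H]1O[C@H](CO)[C@@H](O)[C@H]1O` gives 9.8 nM in this assay, the lowest of the three numbers; its neighbour compound 1 lies within the scatter of it, while compound 2 lies far beyond the scatter. Compound 4 `CCCOc1ccc(/C=N/Nc2nc(N)c3ncn([C@@H]4O[C@H](CO)[C@@H](O)[C@H]4O)c3n2)cc1` carries a different aryl group: 4-propoxyphenyl in place of quinolin-6-yl on a carbon with a double bond to nitrogen. Within the data shown here, no measured pair in the set isolates this exchange, so the step must be judged from the whole picture. The aryl groups of compound 1 and compound 3 both give low numbers, whereas compound 2, which also carries an alkoxy-substituted phenyl, gives a much higher number; compound 4 sits structurally between these cases. Compound 4 is therefore expected to come out weaker than compound 3, with an estimated step of a 6.1-fold higher number from compound 3 to compound 4 (0.79 log units; beyond the scatter). The estimate for compound 4 in this assay is 60 nM, within a range from 10 nM to 500 nM.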

Compound 4, inhibition constant: > 10000 nM
Compound 4: only a limit was reported; the forecaster's own chance of this, stated with the estimate: 3%; at least 160-fold (2.22 log units) between middle value and limit.
By their numbers in this assay, from the lowest: compounds 3 and 1 (each within the scatter of the next); then compound 2. At a limit, above all of these: compound 4.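

In this assay, among these compounds, putting 4-propoxyphenyl in place of quinolin-6-yl on a carbon with a double bond to nitrogen gives an at least 1000-fold higher number from compound 3 to compound 4 (3.00 log units; beyond the scatter), the first step that can be read at a single place. For compound 4 the reported result is a limit of the assay and not a number: the limit of > 10000 nM in this assay, at which 1 of the 4 values shown sits. The two groups have the same count of heavy atoms and of hydrogen-bond acceptors and neither carries a net charge, so these counts do not separate a low number from a limit at this position.

The compounds shown do not tell whether the propoxy chain or the absence of the quinoline ring nitrogen accounts for the step. They also leave open how a plain phenyl or a 4-methoxyphenyl group would behave at this place.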